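The source may report more compounds than this note shows. Statements on the series, on what has been measured and on what is new or still open speak of the compounds shown alone.

Working notes on the series.

Compound 3 `COc1cc(C2OC(c3ccc(N(C)C)cc3)=NN2C=O)cc(OC)c1OC` sits second highest of the three numbers in a functional assay on NCI-H460 cells (Homo sapiens); a higher number here means that more compound is needed for the effect, a lower number that less compound is needed. Going by the values given here, its nearest neighbour is compound 1 `COc1cc(C2OC(c3ccc(N)c(C)c3)=NN2C(C)=O)cc(OC)c1OC`, which gives 0.059 uM against 0.12 uM for compound 3; the two differ in more than one place, so what they show is only the pair of values. The furthest is compound 2 `CCCCNC(=O)c1c(OC)cc(C2OC(c3ccc(N)c(C)c3)=NN2C(C)=O)cc1OC`, which gives 60 uM in this assay. Among the compounds with values here, the single step measured within one change, a 1000-fold higher number from compound 1 to compound 2 (3.01 log units; beyond the scatter), concerns a substituent on the aromatic ring of the core, not the acyl group on the ring nitrogen.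

Compound 4 `COc1cc(C2OC(c3ccc(N(C)C)cc3)=NN2C(=O)CNC(C)=O)cc(OC)c1OC` is compound 3 with acetamidomethyl in place of hydrogen on a carbonyl carbon. Within the data shown here, no measured step touches this carbonyl carbon, so nothing in the data calibrates the change directly. The only indirect hint is that compound 1, carrying a methyl on the corresponding carbonyl, lies close to compound 3, which suggests that this position tolerates some variation. From the compounds shown here alone, a larger group with a donor and an acceptor is untested here, and the expectation is correspondingly wide.

Compound 4 is expected at 0.3 uM in this assay, within 0.06 uM to 1.5 uM, meaning an estimated step of a 2.5-fold higher number from compound 3 to compound 4 (0.40 log units; beyond the scatter).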

Compound 4, concentration for half-maximal effect: 0.48 uM
Beside the measured number, compound 4's estimate is 1.6-fold (0.20 log units) below it; the measured number falls inside the stated range.
By their numbers in this assay, from the lowest: compound 1; then compound 3; then compound 4; then compound 2.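

In this assay, going by these compounds alone, acetamidomethyl in place of hydrogen on this carbonyl carbon gives a 4.0-fold higher number from compound 3 to compound 4 (0.60 log units; beyond the scatter), which is the first reading of a change at this position within a single structural difference. The step is modest and beyond the scatter, so this carbonyl carbon accepts a group of 5 heavy atoms, with a hydrogen-bond donor and a hydrogen-bond acceptor, at a measurable cost, and compound 4 still gives 0.48 uM. No measurement shown here bears on what lies behind this step.

From the compounds shown here alone, it remains open whether the higher number follows the amide within acetamidomethyl or simply the larger group, and an aminomethyl group, a carboxylic acid or a longer alkyl chain on this carbonyl carbon would help separate the two. Compound 1 carries a methyl on its carbonyl and gives 0.059 uM, but it differs from compound 3 in more than one place, so the effect of a methyl alone at this position also remains unsettled.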